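Nitro to Methoxy: Estimating Compound 4

The source may report more compounds than this note shows. Statements on the series, on what has been measured and on what is new or still open speak of the compounds shown alone.

In a functional assay on the whole organism (strain albino) for inhibition, with Rattus norvegicus as the target, read by paw edema, with stated times of 1 h and 2 h, at a dose of 20 mmol/kg by the intraperitoneal route (a higher number here means more inhibition at the dose given (going by the name of the read-out), a lower number less inhibition), compound 3 `N#CC1=C(/N=C/Nc2ccc([N+](=O)[O-])cc2)N(c2ccccc2)C(=O)N2CCCCC(N3CCCC3)C12` gives 41.5%, the second highest of three numbers. Compound 2 `N#CC1=C(NCC(=O)O)N(c2ccccc2)C(=O)N2CCCCC(N3CCCC3)C12` gives 81.7%, and compound 1 `N#CC1=C(NCN2CCCC2)N(c2ccccc2)C(=O)N2CCCCC(N3CCCC3)C12` gives 26.6%. Compound 4 `COc1ccc(N/C=N/C2=C(C#N)C3C(N4CCCC4)CCCCN3C(=O)N2c2ccccc2)cc1` differs from compound 3 by methoxy in place of nitro on an aromatic carbon. Within the data shown here, none of the measured steps alters a group on this aromatic ring: a number 14.9 percentage points higher from compound 1 to compound 3 (beyond the scatter) and a number 40.2 percentage points lower from compound 2 to compound 3 (beyond the scatter) replace the whole group on the double-bonded ring carbon, and a number 55.1 percentage points higher from compound 1 to compound 2 (beyond the scatter) concerns a different part of the shared core. The measured steps therefore give no direct guide to exchanging nitro for methoxy, and a step within the scatter is expected, a number 1.5 percentage points lower from compound 3 to compound 4 (within the scatter). Compound 4 is estimated to give 40%, with a likely range from 25% to 58%.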

Compound 4, a percentage reported as inhibition, in the whole organism at one dose (the size of the read-out at that dose, not a potency): 37.2%
For compound 4 the middle estimate is 2.8 percentage points above the measured one; measured number inside the range.
By their numbers in this assay, from the lowest: compound 1; then compounds 4 and 3 (each within the scatter of the next); then compound 2.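

Exchanging 4-nitrophenyl for 4-methoxyphenyl gives a number 4.3 percentage points lower from compound 3 to compound 4 (within the scatter) and is the only change shown on this aromatic ring, so here the ring carbon takes either group without a clear shift in paw edema inhibition. With methoxy in place, swapping the whole group on the double-bonded ring carbon still gives a number 44.5 percentage points lower from compound 2 to compound 4 (beyond the scatter) and a number 10.6 percentage points higher from compound 1 to compound 4 (beyond the scatter) and so keeps the directions seen with nitro. Nothing available explains why this exchange leaves the number within the scatter.

From the compounds shown here alone, whether an amine or a carboxylic acid on the same ring carbon would behave alike stays open. So does whether a chloro group there would.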